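The source may report more compounds than this note shows. Statements on the series, on what has been measured and on what is new or still open speak of the compounds shown alone.

Compound 1 `COc1ccc(C#Cc2ccc(C(=O)N3CCCC(OC)C3)cc2)cc1` gives 5500 nM in a functional assay on TREX cells for negative allosteric modulation of metabotropic glutamate receptor 3 (Rattus norvegicus), read by calcium flux, with a stated time of 2.5 min; a higher number here means a weaker inhibitor, a lower number a stronger inhibitor. Compound 2 `COc1ccc(C#Cc2ccc(C(=O)NC(C)CO)cc2)cc1` gives 7590 nM in this assay, nominally the higher of the two figures, although the step of a 1.4-fold higher number from compound 1 to compound 2 (0.14 log units; within the scatter) does not support a real distinction. Compound 3 `COc1ccc(C#Cc2ccc(C(=O)N3CC[C@H](O)C3)cc2)cc1` carries 3-hydroxypyrrolidin-1-yl in place of (1-(hydroxymethyl)ethyl)amino on a carbonyl carbon. Within the data shown here, the one step that bears on this exchange of the amide substituent is a 1.4-fold higher number from compound 1 to compound 2 (0.14 log units; within the scatter), which stayed inside the scatter; no move beyond the scatter is therefore expected, the anticipated step being a 1.3-fold lower number from compound 2 to compound 3 (0.10 log units; within the scatter). Compound 3 is accordingly estimated at 6000 nM, with a range of 2500 nM to 14000 nM.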

Compound 3, half-maximal inhibitory concentration: 27500 nM
Compound 3: middle estimate off by 4.6-fold (0.66 log units), on the low side; the measured number lies above the stated range.
By their numbers in this assay, from the lowest: compounds 1 and 2 (each within the scatter of the next); then compound 3.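

At this position on a carbonyl carbon, the choice of amide substituent does register in this assay: 3-hydroxypyrrolidin-1-yl gives a 3.6-fold higher number from compound 2 to compound 3 (0.56 log units; beyond the scatter) and a 5.0-fold higher number from compound 1 to compound 3 (0.70 log units; beyond the scatter). Both steps lie beyond the scatter, unlike the earlier exchange, and compound 3 is the weakest inhibitor of the three. No measurement shown accounts for this loss.

Open, from the compounds shown here alone, is whether the step tracks the five-membered ring, its hydroxyl or its defined stereocentre. Unsubstituted pyrrolidine, 3-methoxypyrrolidine, the opposite 3-hydroxypyrrolidine enantiomer and morpholine amides would help separate these.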